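From compound 1 to compound 4: chloro for cyano

A few compounds are considered here, and "the series" means these few. Any claim that something is new, unique, unknown or untested is made for them only; others in the source may bear on it.

In an ADME assay on microsomes from liver (Rattus norvegicus) for metabolic stability (on this read-out higher numbers stand for a longer-lived compound and lower numbers for a shorter-lived compound), compound 1 `N#Cc1ccc(-c2nc(NCCNc3ccc([N+](=O)[O-])c(N)n3)ncc2-c2ncc[nH]2)cc1` gives > 0.5 h as a limit and not a number. Compound 2 `N#Cc1ccc(NCCNc2ncc(-c3ncc[nH]3)c(-c3ccc(Cl)cc3Cl)n2)nc1` gives > 0.5 h as a limit too. Compound 3 `Clc1ccc(-c2nc(NCCNc3ccccn3)ncc2-c2ncc[nH]2)c(Cl)c1` gives > 0.5 h as a limit too. Compound 1 thus stands at the limit of > 0.5 h in this assay, at which 3 of the 3 values shown sit, and gives no exact starting point. Compound 4 `Nc1nc(NCCNc2ncc(-c3ncc[nH]3)c(-c3ccc(Cl)cc3)n2)ccc1[N+](=O)[O-]` carries chloro in place of cyano on an aromatic carbon of compound 1 (chloro in place of cyano on an aromatic carbon), a move from 4-cyanophenyl to 4-chlorophenyl. The nearest measured step that the two limits leave unreadable from compound 2 to compound 3 also removes cyano, but hydrogen enters there and its size cannot be read. No change beyond the scatter is therefore expected in this assay and no direction can be given. The expected step is a step that the limit leaves unreadable from compound 1 to compound 4 on this evidence. Compound 4 is estimated at 0.7 h with an expected range from 0.4 h to 1.5 h on this read-out.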

Compound 4, half-life: > 0.5 h
Compound 4 ended at the assay's limit; the forecaster's own chance of this, stated with the estimate: 85%; the middle value does not contradict the limit.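

No step can be read from compound 1 to compound 4, since both end at a limit and not a number: the limit of > 0.5 h in this assay, at which 4 of the 4 values shown sit. The compounds shown leave open the actual half-life of each compound, and so whether chloro or cyano makes any difference.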